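This account rests on a few compounds, and the source may have more. Where it says the series, first, only, none or still open, it means among the compounds named here.

Among the measured compounds shown here, compound 2, with the structure `CC(OC(=O)N1CCN(C(=O)c2nc(Nc3cc(C4CC4)[nH]n3)c3cc(Cl)ccc3n2)C[C@H]1C)OC(=O)C(C)(C)C`, is one of two compounds measured in an assay for inhibition of serine/threonine-protein kinase PAK 4 (Homo sapiens), read by FRET and Z'-LYTE, with a stated time of 60 min, tested at 5 uM, in the presence of a further agent that is not named here (on this read-out higher numbers stand for a stronger effect at the one concentration tested and lower numbers for a weaker effect), where compound 2 gives 23.6%. For the measured compounds named here, its only neighbour, compound 1 with the structure `C[C@@H]1CN(C(=O)c2nc(Nc3cc(C4CC4)[nH]n3)c3cc(Cl)ccc3n2)CCN1C(=O)OC(C)(C)C`, gives 22.7% in this assay; the two numbers lie within the scatter of each other, so neither can be called the stronger. The unmeasured compound 3 has the structure `C[C@@H]1CN(C(=O)c2nc(Nc3cc(C4CC4)[nH]n3)c3cc(Cl)ccc3n2)CCN1C(=O)OCc1ccccc1`. Its change from compound 2 is benzyl in place of 1-(((tert-butyl)carbonyl)oxy)ethyl on an oxygen next to a carbonyl group. Going by the values given here, the one measured step that bears on it, a number 0.9 percentage points higher from compound 1 to compound 2 (within the scatter), also reshaped the group on this oxygen next to a carbonyl group and moved the number only within the scatter. For the step of a number 1.6 percentage points lower from compound 2 to compound 3 (within the scatter) no movement beyond the scatter is therefore expected. Compound 3 is estimated to give 22%, with a range from 8% to 38%.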

Compound 3, a percentage reported as inhibition, at one concentration (the size of the read-out at that concentration, not a potency): 74%
Compound 3: middle estimate off by 52 percentage points, on the low side; the whole stated range lies below it.
By their numbers in this assay, from the lowest: compounds 1 and 2 (each within the scatter of the next); then compound 3.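

In this assay the group on this oxygen next to a carbonyl group clearly matters: benzyl in place of 1-(((tert-butyl)carbonyl)oxy)ethyl gives a large rise (a number 50.4 percentage points higher from compound 2 to compound 3 (beyond the scatter)), and benzyl in place of tert-butyl gives another (a number 51.3 percentage points higher from compound 1 to compound 3 (beyond the scatter)). Among the compounds shown here, the earlier pair suggested that this place tolerated change without effect, yet that held only for two groups with no ring; benzyl, the one group here with a six-membered aromatic ring of carbon only, stands clearly apart from both. No measured evidence accounts for this jump.

The compounds shown leave open whether the ring alone is enough, or whether a phenyl group, a longer 2-phenylethyl chain or a pyridylmethyl group would keep the higher number. They also show only a stronger or weaker effect at the one concentration tested and leave open how the effect would change at other concentrations.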